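Isobutyl for isopropoxy in the sulfonyl series

The compounds below may be only part of what the source reports. "The series", "measured", "known", "first", "only" and "open" are said of these compounds alone.

Measured so far in an in vitro ADME assay on microsomes from liver (Homo sapiens) for metabolic stability; a higher number here means that the compound lasts longer, a lower number that the compound disappears faster:
compound 1 `C[C@@H](c1ccc(Cl)cc1)N1Cc2cncn2C(CC2(C)COC2)S1(=O)=O` gives 1.27 h
compound 2 `CC(C)CC1n2cncc2CN(Cc2ccccc2)S1(=O)=O` gives 0.05 h
compound 3 `CC(C)OCC1n2cncc2CN([C@@H](C)c2ccc(Cl)cc2)S1(=O)=O` gives 0.0833 h

Compound 3 (0.0833 h) lies within the scatter of compound 2 (0.05 h) and far from compound 1 (1.27 h). The next structure is compound 4 `CC(C)CC1n2cncc2CN([C@@H](C)c2ccc(Cl)cc2)S1(=O)=O`, which has isopropyl in place of isopropoxy on a saturated chain carbon bound to a saturated ring carbon. Cut one bond further out, this reads isopropoxymethyl to isobutyl (isopropyl in place of isopropoxy on a saturated chain carbon bound to a saturated ring carbon).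

For the measured compounds named here, no measured step isolates this exchange. Going by the values given here, the one measured step at this place is large (a 15-fold lower number from compound 1 to compound 3 (1.18 log units; beyond the scatter)), so a change here can move the half-life well beyond the scatter. That step involves 3-methyloxetan-3-yl, however, which compound 4 does not carry. Compound 2 does carry isobutyl, though it also differs from compound 4 elsewhere, and in this assay compound 2 gives 0.05 h. On that basis, no change beyond the scatter is expected here.

The expected step is small (a 1.2-fold lower number from compound 3 to compound 4 (0.08 log units; within the scatter)). For compound 4 the estimated half-life is 0.07 h, with an expected range from 0.035 h to 0.14 h in this assay.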

Compound 4, half-life: 0.1 h
Estimate against measurement, compound 4: 1.4-fold (0.15 log units) below; low and high end bracket the measured number.
By their numbers in this assay, from the lowest: compounds 2, 3 and 4 (each within the scatter of the next); then compound 1.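

In this assay the exchange at this place, on a saturated chain carbon bound to a saturated ring carbon, now has a direct reading: isopropyl in place of isopropoxy gives a 1.2-fold higher number from compound 3 to compound 4 (0.08 log units; within the scatter), so removing the oxygen of the isopropoxy group, with its one hydrogen-bond acceptor, leaves the half-life within the scatter. The second reading, a 13-fold lower number from compound 1 to compound 4 (1.10 log units; beyond the scatter), is large and in the same direction as a 15-fold lower number from compound 1 to compound 3 (1.18 log units; beyond the scatter), which means that 3-methyloxetan-3-yl now stands apart from two different groups at this place, not only from isopropoxy. No supporting measurement bears on either new step, and the numbers give their size without any cause.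

As far as these compounds go, it remains open whether the longer half-life of compound 1 depends on the ring oxygen of 3-methyloxetan-3-yl or on its ring carbons and methyl group, a question that a 1-methylcyclobutyl group at this place would address. Also open, from the compounds shown here alone, is how a morpholine or a carboxylic acid at this place would read in this assay.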